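Dropping a methoxy from compound 1: what to expect

A few compounds are considered here, and "the series" means these few. Any claim that something is new, unique, unknown or untested is made for them only; others in the source may bear on it.

Measured so far, in a functional assay on DLD-1 cells (Homo sapiens) for cytotoxicity, read by colorimetric assay and MTT assay, with a stated time of 3 days, tested at 1 uM; on this read-out higher numbers stand for a weaker effect at the one concentration tested and lower numbers for a stronger effect:
- compound 1, `COc1ccc(-c2nc(-c3ccccc3)c(-c3ccc4c(c3)NC(=O)CO4)[nH]2)cc1`, gives 96%
- compound 2, `O=C1COc2ccc(-c3nn(-c4ccc(Br)cc4)cc3-c3ccccc3)cc2N1`, gives 66.4%
- compound 3, `O=C1COc2ccc(-c3nn(-c4cc(Cl)cc(Cl)c4)cc3-c3ccccc3)cc2N1`, gives 90.3%

Compound 1 stands highest of the three numbers, which on this read-out means the weakest effect at the single concentration tested. Its nearest neighbour is compound 3, whose number lies within the scatter of compound 1, so no order can be claimed between these two. Compound 2 lies furthest away, beyond the scatter, with the stronger effect of the three.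

Going by the values given here, the only measured step, a number 23.9 percentage points higher from compound 2 to compound 3 (beyond the scatter), concerns a change on an aromatic nitrogen and says nothing about the change now at hand. Compound 4, `O=C1COc2ccc(-c3[nH]c(-c4ccccc4)nc3-c3ccccc3)cc2N1`, differs from compound 1 in one place: hydrogen in place of methoxy on an aromatic carbon. Among the compounds with values here, no measured pair shows what removing a methoxy does here, so the expectation rests only on the fact that compound 1 already sits near the weak end of the scale.

Compound 4 is therefore expected to give a number close to that of compound 1, with a number 4 percentage points lower from compound 1 to compound 4 (within the scatter) expected to fall within the usual scatter. The estimate for compound 4 is 92%, with a range from 78% to 104%.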

Compound 4, a percentage reported as activity, at one concentration (the size of the read-out at that concentration, not a potency): 98.2%
Compound 4: the middle estimate sits 6.2 percentage points below what was measured, within the range that was stated.
By their numbers in this assay, from the lowest: compound 2; then compounds 3, 1 and 4 (each within the scatter of the next).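

In this assay, going by these compounds alone, going from 4-methoxyphenyl to phenyl gives a number 2.2 percentage points higher from compound 1 to compound 4 (within the scatter), so this is the first direct look at this position, and taking the methoxy off this aromatic carbon, para to a large group, produces no change that can be told from the scatter. The methoxy is therefore not needed to keep the read-out where it stands, and the earlier step, made on an aromatic nitrogen, could not have shown this. Both compounds give high numbers, meaning little effect on the cells at the one concentration tested, and no measurement here offers a reason for the lack of change.

What the compounds shown leave open is whether a different group on this same carbon, such as an amine, a carboxylic acid or a longer chain like butoxy, would move the number beyond the scatter towards a stronger effect. Also open, on these data alone, is whether removing the methoxy would matter at a higher concentration, since a single concentration near the weak end of the scale gives no measure of potency.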